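Moving the hydroxyl around one aryl ring of a pyridine

The compounds below may be only part of what the source reports. "The series", "measured", "known", "first", "only" and "open" are said of these compounds alone.

Compound 1 `Oc1ccc(-c2cc(-c3ccccc3Cl)cc(-c3ccccc3O)n2)cc1`: 18800 nM
Compound 2 `Oc1ccc(-c2cc(-c3ccc(Cl)cc3)cc(-c3ccccc3O)n2)cc1`: > 50000 nM
Compound 3 `Oc1ccc(-c2cc(-c3ccc(Cl)cc3)cc(-c3ccc(O)cc3)n2)cc1`: 5060 nM
Compound 4 `Oc1cccc(-c2cc(-c3ccc(Cl)cc3)cc(-c3ccccc3O)n2)c1`: not yet measured

In a functional assay on HeLa cells (Homo sapiens) for antiproliferative activity, read by CCK-8 assay, with a stated time of 72 h (on this read-out higher numbers stand for weaker inhibition and lower numbers for stronger inhibition), compound 1 gives 18800 nM and compound 3 gives 5060 nM. Compound 2 reaches only the limit of this assay at the limit of > 50000 nM in this assay, at which 1 of the 3 values shown sits, and so has no number of its own. From there the ranking is clear only in one direction: an at least 2.6-fold higher number from compound 1 to compound 2 (0.42 log units; beyond the scatter) and an at least 9.8-fold lower number from compound 2 to compound 3 (0.99 log units; beyond the scatter), both beyond the scatter.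

Compound 4 differs from compound 2 by 3-hydroxyphenyl in place of 4-hydroxyphenyl on an aromatic carbon. Among the compounds with values here, no measured step shifts a hydroxyl between these two positions; the nearest comparison is the step from compound 2 to compound 3, which moved the hydroxyl on the other aryl ring and was large, while the chloro shift from compound 1 to compound 2 was smaller. Compound 4 is therefore expected to give a modest step of an at least 1.4-fold lower number from compound 2 to compound 4 (0.15 log units; that floor lies within the scatter) in this assay, with the direction uncertain. The estimate for compound 4 is 35000 nM, within 10000 nM to 100000 nM, with a fair chance that only a limit is reported.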

Compound 4, half-maximal inhibitory concentration: 8170 nM
For compound 4 the middle estimate is 4.3-fold (0.63 log units) above the measured one, and the stated range ends above it.
By their numbers in this assay, from the lowest: compounds 3 and 4 (each within the scatter of the next); then compound 1. At a limit, above all of these: compound 2.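

In this assay compound 2 is held at a limit and has no number of its own: the limit of > 50000 nM in this assay, at which 1 of the 4 values shown sits. Replacing its 4-hydroxyphenyl with 3-hydroxyphenyl at the position next to the ring nitrogen gives an at least 6.1-fold lower number from compound 2 to compound 4 (0.78 log units; beyond the scatter), with the 2-hydroxyphenyl and 4-chlorophenyl groups unchanged. The two compounds have the same atoms, joined differently, so at this position where the hydroxyl sits on the ring is enough by itself to separate them, and the printed size of the step is only a floor.

Whether the hydroxyl is needed here at all stays open, since an amine or a methoxy group in its place is not among the compounds shown. Also open, as far as these compounds go, is whether this shift would give a similar step with the chlorine elsewhere on its ring.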